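Swapping the Amine Ring at the End of the Side Chain

The compounds below may be only part of what the source reports. "The series", "measured", "known", "first", "only" and "open" are said of these compounds alone.

Compound 2 `O=c1cc(-c2ccccc2)oc2c(OCCCN3CCCC3)c(OCc3ccccc3)cc(O)c12` carries a propyl chain from an oxygen on the aromatic core, ending in a pyrrolidin-1-yl group. In a functional assay on B16 cells (Mus musculus) for cytotoxicity, read by MTT assay, with a stated time of 72 h (a lower number here means a stronger inhibitor, a higher number a weaker inhibitor), compound 2 gives 7980 nM. Its only measured relative, compound 1 `CCN(CC)CCCOc1c(OCc2ccccc2)cc(O)c2c(=O)cc(-c3ccccc3)oc12`, has a diethylamino end on the same chain, and in this assay compound 1 gives 4900 nM. The step of a 1.6-fold higher number from compound 1 to compound 2 (0.21 log units; within the scatter) is within the scatter, so the two values cannot be told apart. Compound 3 `CN1CCN(CCCOc2c(OCc3ccccc3)cc(O)c3c(=O)cc(-c4ccccc4)oc23)CC1` changes the same end once more: 4-methylpiperazin-1-yl in place of pyrrolidin-1-yl on a saturated chain carbon, three bonds along the chain from an oxygen on an aromatic ring. For the measured compounds named here, the one measured step at this position was small, so a step of similar size in this assay, or none beyond the scatter, is expected here. Compound 3 is therefore estimated at 9000 nM, with a range from 3500 nM to 25000 nM. That estimate means an expected step of a 1.1-fold higher number from compound 2 to compound 3 (0.05 log units; within the scatter), too small to count as a real change.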

Compound 3, half-maximal inhibitory concentration: 3760 nM
Compound 3: the middle estimate sits 2.4-fold (0.38 log units) above what was measured, within the range that was stated.
By their numbers in this assay, from the lowest: compounds 3, 1 and 2 (each within the scatter of the next, the first and the last beyond it).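

In this assay, a change at the end of the chain now gives a 2.1-fold lower number from compound 2 to compound 3 (0.33 log units; beyond the scatter) as a step beyond the scatter, though a modest one, when 4-methylpiperazin-1-yl takes the place of pyrrolidin-1-yl. The same group in place of diethylamino gives a 1.3-fold lower number from compound 1 to compound 3 (0.12 log units; within the scatter) and stays within the scatter, so among these three ends only the 4-methylpiperazin-1-yl and pyrrolidin-1-yl groups can be told apart. No measurement is at hand to say what lies behind this one real step.

On these data alone, whether a piperidin-1-yl, morpholin-4-yl or dimethylamino end would fall inside or outside this small spread stays open. So does the result of a longer chain, such as a butyl chain carrying the 4-methylpiperazin-1-yl group in place of the propyl chain.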